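Chloro in place of hydrogen on the shared core

The source may report more compounds than this note shows. Statements on the series, on what has been measured and on what is new or still open speak of the compounds shown alone.

Measured so far:
compound 1, `ClCc1ccc(Cn2cnc3nc(Cl)nc(Cl)c32)cc1`: 3160 nM
compound 2, `ClCc1ccccc1Cn1cnc2ncnc(Cl)c21`: 5120 nM

In a functional assay on M14 cells (Homo sapiens) for cytotoxicity, read by sulforhodamine B assay, with a stated time of 48 h (a lower number here means a stronger inhibitor of growth, a higher number a weaker inhibitor of growth), compound 1 gives 3160 nM and compound 2 gives 5120 nM. Compound 2 carries the highest of the two numbers, but its nearest neighbour, compound 1, lies within the scatter of it, so the two read as equivalent. Going by the values given here, the two compounds differ in more than one place, so no single step between them can be named.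

Compound 3, `ClCc1ccccc1Cn1cnc2nc(Cl)nc(Cl)c21`, is the next entry for this assay. It differs from compound 2 in one place: chloro in place of hydrogen on an aromatic carbon. Compound 1 already carries this same pair of chloro groups on the shared core and gives 3160 nM, a number within the scatter of compound 2. On that basis the step from compound 2 to compound 3 is expected to be small, as a 1.6-fold lower number from compound 2 to compound 3 (0.20 log units; within the scatter), with no clear direction beyond the scatter. Compound 3 is therefore estimated at 3200 nM, in a range from 1300 nM to 8000 nM.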

Compound 3, concentration for total growth inhibition: 3460 nM
The estimate for compound 3 lay 1.1-fold (0.03 log units) below the measured number; the measured number falls inside the stated range.
By their numbers in this assay, from the lowest: compounds 1, 3 and 2 (each within the scatter of the next).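

In this assay the exchange of hydrogen for chloro on the aromatic carbon between two ring nitrogen atoms gives a 1.5-fold lower number from compound 2 to compound 3 (0.17 log units; within the scatter) and so leaves compound 2 and compound 3 equivalent. Going by these compounds alone, this is the first reading of a single change, and it shows that this position can carry a chloro group with no effect on growth inhibition that stands clear of the scatter. No measurement shown bears on why the step is this small.

Only hydrogen and chloro are shown at this position, so the reading of an amine, a methoxy group or a longer chain there remains open. Within the data shown here, no single step here speaks to the remaining chloro group on the shared core or to the chloromethyl group, so their part in the growth inhibition also remains open.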